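The source may hold more compounds than are shown below. What is called first, only, known or untested is meant among the compounds shown, and "the series" means these compounds.

Measured so far in an assay for binding affinity to protein lin-28 homolog A (Mus musculus), with a stated time of 1 h; on this read-out higher numbers stand for weaker inhibition and lower numbers for stronger inhibition:
compound 1, `O=S(=O)(Nc1ccccc1NS(=O)(=O)c1ccc(F)cc1)c1ccccc1` — 13900 nM
compound 2, `O=S(=O)(Nc1ccccc1NS(=O)(=O)c1ccc(Cl)cc1)c1ccc(F)cc1` — 27300 nM

Compound 2 holds the highest of the two numbers in this assay, with compound 1 the nearest, and the step of a 2.0-fold higher number from compound 1 to compound 2 (0.29 log units; within the scatter) lies within the scatter. Both compounds share the same core; they differ only in the substituent on the aromatic carbon para to a large group, hydrogen in compound 1 and chloro in compound 2.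

Compound 3, `COc1ccc(S(=O)(=O)Nc2ccccc2NS(=O)(=O)c2ccc(F)cc2)cc1`, is to be measured in this assay. The change from compound 2 is methoxy in place of chloro on an aromatic carbon. For the measured compounds named here, no measured step covers methoxy in place of chloro. Going by the values given here, the one step that touches the same position, a 2.0-fold higher number from compound 1 to compound 2 (0.29 log units; within the scatter), was within the scatter, so the data give no sign that a substituent at this place moves the number much. On that basis compound 3 is expected to stay near compound 2, with a step of a 1.4-fold lower number from compound 2 to compound 3 (0.14 log units; within the scatter) that is not expected to exceed the scatter. The estimate for compound 3 in this assay is 20000 nM, with a range from 7000 nM to 60000 nM.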

Compound 3, half-maximal inhibitory concentration: 17200 nM
Compound 3: the middle estimate sits 1.2-fold (0.07 log units) above what was measured; low and high end bracket the measured number.
By their numbers in this assay, from the lowest: compounds 1, 3 and 2 (each within the scatter of the next).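

With methoxy in this assay, the position on the aromatic carbon para to a large group now has three substituents to compare, and the steps of a 1.6-fold lower number from compound 2 to compound 3 (0.20 log units; within the scatter) and a 1.2-fold higher number from compound 1 to compound 3 (0.09 log units; within the scatter) both stay within the scatter, as does the earlier step from hydrogen to chloro. Methoxy enters with 1 hydrogen-bond acceptor where chloro has none, and a second kind of replacement for hydrogen thus leaves the number no further from compound 1 than the scatter allows, so among hydrogen, chloro and methoxy the read-out gives no order at this place. No measurement available for these compounds explains this flat result, and none bears on why the three substituents cannot be told apart.

Still open, from the compounds shown here alone, is whether this place stays as insensitive with an amine, a carboxylic acid or a longer alkoxy chain, groups that differ from the three tried here. Going by these compounds, the fluoro on the other ring is the same in all three compounds, so what a change there would do to the number, alone or combined with a change at this position, also remains unknown.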